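The compounds below may be only part of what the source reports. "The series", "measured", "known", "first", "only" and "open" are said of these compounds alone.

Compound 1 `N#CC1=C(N)Oc2c(c3nc4ccccc4nc3c3ccccc23)C12C(=O)N(Cc1cnnn1-c1ccccc1Br)c1ccccc12` in a functional assay on HCT-116 cells (Homo sapiens) for antiproliferative activity, read by MTT assay, with a stated time of 48 h (a higher number here means a weaker inhibitor, a lower number a stronger inhibitor), gives > 50000 nM, which is a limit of the assay and not a number. Compound 2 `Cc1ccc(-n2nncc2CN2C(=O)C3(C(C#N)=C(N)Oc4c3c3nc5ccccc5nc3c3ccccc43)c3ccccc32)cc1C` in this assay gives > 50000 nM, again a limit and not a number. Compound 3 `N#CC1=C(N)Oc2c(N)cc3nc4ccccc4nc3c2C12C(=O)N(Cc1cnnn1-c1cccc(Br)c1)c1ccccc12` in this assay gives 26100 nM.

Within the data shown here, compound 3 is thus the only compound with a measured number in this assay; the other two sit at the limit of > 50000 nM in this assay, at which 2 of the 3 values shown sit. Among the measured compounds shown here, the one step between measured compounds, a step that the two limits leave unreadable from compound 1 to compound 2, runs between two limits, so its size cannot be read. Compound 4 `CCOc1ccc(-n2nncc2CN2C(=O)C3(C(C#N)=C(N)Oc4c(N)cc5nc6ccccc6nc5c43)c3ccccc32)cc1` differs from compound 3 in one place: 4-ethoxyphenyl in place of 3-bromophenyl on an aromatic nitrogen. For the measured compounds named here, no measured step bears directly on this change: the only step available, a step that the two limits leave unreadable from compound 1 to compound 2, also swaps the group on the aromatic nitrogen but gives no readable size. Going by the values given here, what the data do show is that three different groups at that place all leave the compounds weak in this assay, and compound 3 is the only one that yields a number at all. The step from compound 3 to compound 4 is therefore expected to be small or not readable, with compound 4 remaining weak. Compound 4 is estimated at 30000 nM with a range from 10000 nM to 100000 nM, a step of a 1.1-fold higher number from compound 3 to compound 4 (0.06 log units; within the scatter), which is expected to stay within the scatter. There is a real chance that compound 4 returns only a limit.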

Compound 4, half-maximal inhibitory concentration: > 50000 nM
Compound 4: a limit, no number (the forecaster's own chance of this, stated with the estimate: 40%); middle value at least 1.6-fold (0.22 log units) from the limit.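

Among these compounds, putting 4-ethoxyphenyl in place of 3-bromophenyl gives an at least 1.9-fold higher number from compound 3 to compound 4 (0.28 log units; that floor lies within the scatter), the first change at this position whose size can be read even in part. The value for compound 4 is a limit and not a number, so this step has only a floor, and the true size could be small or much larger; since the floor lies within the scatter, the result does not establish that the change weakens the compound. It does show that a phenyl group carrying an ethoxy chain, which adds one hydrogen-bond acceptor, does not bring a measurable number in this assay, and the set now rests largely on a single limit: the limit of > 50000 nM in this assay, at which 3 of the 4 values shown sit.

Among the compounds shown here, compound 3 remains the only compound with a number, so how strongly this position can shift activity stays open. Also open, on these data alone, is whether a phenyl ring carrying an amine or a carboxylic acid, or a longer chain in place of the phenyl ring on this aromatic nitrogen, would give a stronger inhibitor than compound 3.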